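Triazine amine variation: diethylamino analogue of compound 3

This account rests on a few compounds, and the source may have more. Where it says the series, first, only, none or still open, it means among the compounds named here.

Compound 3 `CCCCN(CC#N)c1nc(C)nc(N(CC)c2ccc(N(C)C)cc2C(F)(F)F)n1` gives 6 nM in an assay on isolated protein for binding affinity to corticotropin-releasing factor receptor 1 (Homo sapiens); a lower number here means a stronger inhibitor, a higher number a weaker inhibitor. Compound 2 `CCN(CC)c1nc(C)nc(N(CC)c2ccc(N(C)C)cc2Br)n1` gives 6 nM, the same at the digits shown, and compound 1 `CCN(c1nc(C)nc(N(CC2CC2)CC2CC2)n1)c1ccc(N(C)C)cc1C(F)(F)F` gives 5 nM; all three numbers sit within the scatter of one another, so no order among them can be read.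

Compound 4 `CCN(CC)c1nc(C)nc(N(CC)c2ccc(N(C)C)cc2C(F)(F)F)n1` differs from compound 3 by diethylamino in place of butyl(cyanomethyl)amino on an aromatic carbon. The shared core and the aryl group with its trifluoromethyl and dimethylamino groups are unchanged.

For the measured compounds named here, one measured step bears on this kind of change at the same position: a 1.2-fold higher number from compound 1 to compound 3 (0.08 log units; within the scatter), where bis(cyclopropylmethyl)amino gave way to butyl(cyanomethyl)amino without a shift beyond the scatter. Compound 2 carries the same diethylamino group that enters in compound 4, with bromo instead of trifluoromethyl on the aryl ring. In this assay compound 2 gives 6 nM, which matches compound 3. The expected step of a 1.2-fold lower number from compound 3 to compound 4 (0.08 log units; within the scatter) therefore lies within the scatter. Compound 4 is estimated at 5 nM, with a range from 2.5 nM to 12 nM.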

Compound 4, inhibition constant: 20 nM
For compound 4 the middle estimate is 4.0-fold (0.60 log units) below the measured one; measured number above the stated range.
By their numbers in this assay, from the lowest: compounds 1, 2 and 3 (each within the scatter of the next); then compound 4.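

In this assay the amine on the aromatic carbon between two ring nitrogen atoms proves not to be freely interchangeable: diethylamino gives a 3.3-fold higher number from compound 3 to compound 4 (0.52 log units; beyond the scatter) and a 4.0-fold higher number from compound 1 to compound 4 (0.60 log units; beyond the scatter) while the two larger amines stay within the scatter of each other. With diethylamino fixed, the aryl group also counts, as trifluoromethyl in place of bromo gives a 3.3-fold higher number from compound 2 to compound 4 (0.52 log units; beyond the scatter) so the level of compound 2 does not carry over to this aryl group. No available evidence accounts for either change.

Going by these compounds, whether the nitrile or the butyl chain of butyl(cyanomethyl)amino holds the level of compound 3 stays open. Also open, on these data alone, is where a cyclic amine such as morpholine or a smaller one such as dimethylamino would fall at this position.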